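This account rests on a few compounds, and the source may have more. Where it says the series, first, only, none or still open, it means among the compounds named here.

Three related compounds have numbers in a functional assay on HT-29 cells (Homo sapiens) for cytotoxicity, read by MTT assay, with a stated time of 72 h; on this read-out higher numbers stand for weaker inhibition of growth and lower numbers for stronger inhibition of growth. Compound 1, `CC(C)COC(=O)Nc1ccc([Se][Se]c2ccc(NC(=O)OCC(C)C)cc2)cc1`, gives 19900 nM in this assay. Compound 3, `O=C(Nc1ccc([Se][Se]c2ccc(NC(=O)OCc3ccccc3)cc2)cc1)OCc1ccccc1`, gives 1800 nM in this assay. Compound 2, `CCCOC(=O)Nc1ccc([Se]C#N)cc1`, gives 28400 nM in this assay, the highest of the three numbers; its nearest neighbour is compound 1, whose number is lower by an amount that lies within the scatter of repeated measurements, while compound 3 stands far below it, beyond that scatter.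

Compound 4, `CC(C)COC(=O)Nc1ccc([Se]C#N)cc1`, has not yet been measured. It differs from compound 2 by methyl in place of hydrogen on a saturated chain carbon bound to two saturated chain carbons, so that the propyl carbamate of compound 2 becomes an isobutyl carbamate. Within the data shown here, no pair among the measured compounds shows this change alone, so there is no measured step to lean on. Compound 1 and compound 3 differ in the ester part of the carbamate and their numbers lie far apart, but that pair does not isolate a single methyl added to a chain, and both also differ from compound 2 in the selenium-bearing part. The step expected here is a 1.1-fold lower number from compound 2 to compound 4 (0.06 log units; within the scatter), small and without a direction that would stand beyond the scatter. Compound 4 is therefore expected to give about 25000 nM in this assay, within a range from 10000 nM to 60000 nM.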

Compound 4, concentration for 50% growth inhibition: 8100 nM
Beside the measured number, compound 4's estimate is 3.1-fold (0.49 log units) above it; the measured number lies below the stated range.
By their numbers in this assay, from the lowest: compound 3; then compound 4; then compounds 1 and 2 (each within the scatter of the next).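

In this assay, adding a methyl on a saturated chain carbon bound to two saturated chain carbons, which turns the propyl carbamate into an isobutyl carbamate, gives a 3.5-fold lower number from compound 2 to compound 4 (0.54 log units; beyond the scatter), a modest step but one that clears the scatter. Among these compounds, this is the first measured step in the set that isolates a single change, and it shows that this part of the carbamate chain can shift the number even when the change is only one carbon and the selenium-bearing part stays the same, something the earlier compounds, with no single-place pair among them, could not show. Nothing measured here accounts for the size or direction of this step.

The compounds shown include no straight butyl carbamate with the selenium-bearing part of compound 2, so they cannot tell whether the branch or simply the added carbon matters. They also leave open how a benzyl carbamate, or a shorter ethyl chain, would read with that same selenium-bearing part, and whether the step from propyl to isobutyl would hold on the core of compound 1.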